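A few compounds are considered here, and "the series" means these few. Any claim that something is new, unique, unknown or untested is made for them only; others in the source may bear on it.

Working notes. In a functional assay on Jurkat cells (Homo sapiens) for inhibition, read by CCK-8 assay, with a stated time of 48 h (a higher number here means a weaker inhibitor of growth, a lower number a stronger inhibitor of growth), compound 1 `Cc1ccccc1Nc1nc(Nc2ccc(N3CCNCC3)cn2)ncc1Cl` gives 7870 nM, and compound 2 `Cc1ccccc1Nc1nc(Nc2ccc(N3CCCN(C)CC3)cc2)ncc1Cl` gives 11300 nM. For compound 3 `CN1CCN(c2ccc(Nc3ncc(Cl)c(NCc4ccco4)n3)nc2)CC1` this assay reports only > 100000 nM, which is a limit and not a number. Compound 3 thus stands at the limit of > 100000 nM in this assay, at which 1 of the 3 values shown sits. Compound 4 `COc1cccc(Nc2nc(Nc3ccc(N4CCN(C)CC4)cn3)ncc2Cl)c1` has not yet been measured in this assay. The change from compound 3 is 3-methoxyphenyl in place of (furan-2-yl)methyl on a nitrogen on an aromatic ring. Compound 1 and compound 2 both carry a six-membered aromatic ring of carbon only on that nitrogen and both give numbers rather than limits. The expected step is an at least 11-fold lower number from compound 3 to compound 4 (1.04 log units; beyond the scatter), a move towards stronger inhibition beyond the scatter. Compound 4 is expected near 9000 nM, between 3000 nM and 30000 nM, because compound 1 gives 7870 nM.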

Compound 4, concentration for 50% growth inhibition: 15800 nM
For compound 4 the middle estimate is 1.8-fold (0.24 log units) below the measured one; the range from low to high includes it.
By their numbers in this assay, from the lowest: compounds 1, 2 and 4 (each within the scatter of the next). At a limit, above all of these: compound 3.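

In this assay, 3-methoxyphenyl in place of (furan-2-yl)methyl on a nitrogen on an aromatic ring gives an at least 6.3-fold lower number from compound 3 to compound 4 (0.80 log units; beyond the scatter). Going by these compounds alone, this is the first step read at this position, and it shows that the group on this nitrogen can move growth inhibition beyond the scatter. The full size of the step stays unknown because compound 3 stands at a limit: the limit of > 100000 nM in this assay, at which 1 of the 4 values shown sits.

The pair does not tell whether the ring or its link to the nitrogen carries the step. As far as these compounds go, how a benzyl group, or an amine or carboxylic acid on the ring, would read remains open.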